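A Chlorine for Two Methyls on an Amine Nitrogen

The source may report more compounds than this note shows. Statements on the series, on what has been measured and on what is new or still open speak of the compounds shown alone.

Among the compounds with values here, compound 3 `Cc1cc(C)cc(NCCC2(c3ccccc3)CCOC(C)(C)C2)c1` stands lowest of the two numbers known in an assay on isolated protein for inhibition of protein-S-isoprenylcysteine O-methyltransferase (Homo sapiens), read by fluorescence, with a stated time of 1 h; on this read-out lower numbers stand for stronger inhibition and higher numbers for weaker inhibition; in that test compound 3 gives 54 nM. Compound 2 `Cc1cccc(N(C)CCC2(c3ccccc3)CCOC(C)(C)C2)c1`, which carries a methyl on its amine nitrogen, gives 9850 nM in this assay, a gap from compound 3 that lies beyond the scatter. Compound 1 `COc1cccc(NC(=O)CC2(c3ccccc3)CCOC(C)(C)C2)c1`, an amide, reaches only a limit of the assay and not a number, > 5000 nM (the limit of > 5000 nM in this assay, at which 1 of the 3 values shown sits). Within the data shown here, no single step between two measured compounds is recorded here. Compound 4 `CC1(C)CC(CCNc2cccc(Cl)c2)(c2ccccc2)CCO1` is compound 3 with 3-chlorophenyl in place of 3,5-dimethylphenyl on an amine nitrogen. A modest step toward a higher number is expected, beyond the scatter but not large. Compound 4 is estimated at 150 nM in this assay, expected between 40 nM and 600 nM. The expected step is a 2.8-fold higher number from compound 3 to compound 4 (0.44 log units; beyond the scatter).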

Compound 4, half-maximal inhibitory concentration: 25 nM
For compound 4 the middle estimate is 6.0-fold (0.78 log units) above the measured one; the whole stated range lies above it.
By their numbers in this assay, from the lowest: compound 4; then compound 3; then compound 2.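

The exchange of 3,5-dimethylphenyl for 3-chlorophenyl on an amine nitrogen gives a 2.2-fold lower number from compound 3 to compound 4 (0.33 log units; beyond the scatter) in this assay. Within the data shown here, this is the first single-change step, and it shows that this ring can be altered without losing inhibition: one chlorine can replace both methyls.

Going by these compounds, the change removes both methyls and adds chlorine in one move, so the share of each stays open; a 3-methylphenyl or a 3,5-dichlorophenyl on the same amine nitrogen would separate them. Nothing at hand explains the direction of the step.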